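Thiophene in Place of Dichlorophenyl: Expected Growth Inhibition

The source may report more compounds than this note shows. Statements on the series, on what has been measured and on what is new or still open speak of the compounds shown alone.

Of the compounds shown here, two have so far been tested in a functional assay on HCT-116 cells (Homo sapiens) for antiproliferative activity, read by MTT assay, with a stated time of 48 h; on this read-out lower numbers stand for stronger inhibition of growth and higher numbers for weaker inhibition of growth. Compound 1 `S=C(Nc1ccccc1)N1N=C(c2ccc(Cl)cc2)CC1c1ccc2c(c1)OCCO2` gives > 200000 nM in this assay, which is a limit of the assay rather than a number (the limit of > 200000 nM in this assay, at which 1 of the 2 values shown sits). Compound 2 `S=C(Nc1ccccc1)N1N=C(c2ccc(Cl)c(Cl)c2)CC1c1ccc2c(c1)OCCO2`, which carries a further chloro group, gives 125000 nM in this assay. The step of an at least 1.6-fold lower number from compound 1 to compound 2 (0.20 log units; that floor lies within the scatter) is the only measured step, and compound 2 therefore holds the only number shown, with the other value being a limit. Compound 3 `S=C(Nc1ccccc1)N1N=C(c2cccs2)CC1c1ccc2c(c1)OCCO2` differs from compound 2 by thiophen-2-yl in place of 3,4-dichlorophenyl on a carbon with a double bond to nitrogen, in words: thiophen-2-yl in place of 3,4-dichlorophenyl on a carbon with a double bond to nitrogen. Among the measured compounds shown here, no measured step touches a change of this kind; the only step concerns a chloro group and was itself not beyond the scatter. For compound 3 the expected step of a 1.6-fold higher number from compound 2 to compound 3 (0.20 log units; within the scatter) in this assay is none beyond the scatter. Compound 3 is estimated at 200000 nM, between 60000 nM and 600000 nM.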

Compound 3, concentration for 50% growth inhibition: 8190 nM
Estimate against measurement, compound 3: 24-fold (1.39 log units) above; the measured number lies below the stated range.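

Placing thiophen-2-yl instead of 3,4-dichlorophenyl on the carbon with a double bond to nitrogen gives a 15-fold lower number from compound 2 to compound 3 (1.18 log units; beyond the scatter) in this assay, so a change at this position can shift growth inhibition well beyond the scatter, which the chloro step alone did not show. Measured against the 4-chlorophenyl group, the same kind of change gives an at least 24-fold lower number from compound 1 to compound 3 (1.38 log units; beyond the scatter), and this is a floor rather than an exact size. That floor rests on compound 1, whose entry is a limit of the assay and not a number: the limit of > 200000 nM in this assay, at which 1 of the 3 values shown sits.

The compounds shown cannot say whether the gain belongs to the five-membered ring with sulfur or simply to the absence of chlorine. A plain phenyl or a furan-2-yl group at this carbon would be needed to separate the two, and how the change acts remains unexplained.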